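This account rests on a few compounds, and the source may have more. Where it says the series, first, only, none or still open, it means among the compounds named here.

Measured compounds in an ADME assay on PANC-1 cells (Homo sapiens) for inhibition, read by MTT assay, with a stated time of 48 h; on this read-out lower numbers stand for stronger inhibition of growth and higher numbers for weaker inhibition of growth:
compound 1 `O=[N+]([O-])c1ccc(Cn2cc(COc3ccccc3)nn2)cc1` gives > 100 ug/mL, a limit of the assay and not a number.
compound 2 `Clc1ccc(Cn2cc(COc3ccccc3)nn2)cc1` gives > 100 ug/mL, again a limit.
compound 3 `Clc1cccc(Cn2cc(COc3ccccc3)nn2)c1` gives > 100 ug/mL, also a limit.

Compound 3 therefore stands only as a limit in this assay, and the same is true of the two other values shown (the limit of > 100 ug/mL in this assay, at which 3 of the 3 values shown sit). The step that the two limits leave unreadable from compound 1 to compound 2 and the step that the two limits leave unreadable from compound 2 to compound 3 both run between two limits and so have no readable size; they say only that none of the three compounds reached a measurable concentration for half-maximal growth inhibition.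

Compound 4 `Brc1ccc(Cn2cc(COc3ccccc3)nn2)cc1` differs from compound 3 by 4-bromophenyl in place of 3-chlorophenyl on a saturated chain carbon bound to an aromatic nitrogen. The measured steps that bear on it are the exchange of one chlorophenyl for the other, a step that the two limits leave unreadable from compound 2 to compound 3, and the exchange of halogen for nitro on the same ring, a step that the two limits leave unreadable from compound 1 to compound 2; neither is readable, and neither lifted a compound off the limit. No step beyond the scatter is therefore expected in this assay; the likeliest outcome for compound 4 is a further limit.

Compound 4 is estimated at 150 ug/mL, with a range from 70 ug/mL to 400 ug/mL. The step that the limit leaves unreadable from compound 3 to compound 4 is expected to be one that the limits again leave unreadable.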

Compound 4, concentration for 50% growth inhibition: > 100 ug/mL
Compound 4 was reported as a limit; the forecaster's own chance of this, stated with the estimate: 85%; the middle value lies beyond the limit too.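

Going by these compounds alone, no step from compound 1, compound 2 or compound 3 to compound 4 can be read in this assay, since all four compounds give a limit and not a number: the limit of > 100 ug/mL in this assay, at which 4 of the 4 values shown sit.

The compounds shown leave open how far beyond that limit each one lies, and whether any change on this shared core gives a measurable value.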